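Swapping the phenyl substituent where all values are limits

A few compounds are considered here, and "the series" means these few. Any claim that something is new, unique, unknown or untested is made for them only; others in the source may bear on it.

Compound 2 `COc1ccc(/C=N\NC(=S)NC(C)(C)CCC[C@](C)(O)[C@@H]2CC=C(C)CC2)cc1` carries a 4-methoxyphenyl group on the carbon double-bonded to nitrogen. In a functional assay on MCF7 cells (Homo sapiens) for cytotoxicity, read by sulforhodamine B assay (a higher number here means that more compound is tolerated, a lower number that less compound is tolerated), compound 2 gives only a limit, > 100000 nM, and not a number. Compound 1 `CC1=CC[C@@H]([C@@](C)(O)CCCC(C)(C)NC(=S)N/N=C\c2ccc(C)cc2)CC1` likewise gives only a limit in this assay, namely > 100000 nM. Compound 3 `CC1=CC[C@@H]([C@@](C)(O)CCCC(C)(C)NC(=S)N/N=C\c2ccccc2[N+](=O)[O-])CC1` also gives only a limit in this assay, namely > 100000 nM. All three values therefore sit at the limit of > 100000 nM in this assay, at which 3 of the 3 values shown sit, and the steps between them, a step that the two limits leave unreadable from compound 1 to compound 2, a step that the two limits leave unreadable from compound 1 to compound 3 and a step that the two limits leave unreadable from compound 2 to compound 3, cannot be read in size. Compound 4 `CC1=CC[C@@H]([C@@](C)(O)CCCC(C)(C)NC(=S)N/N=C\c2cccc(Cl)c2)CC1` differs from compound 2 by 3-chlorophenyl in place of 4-methoxyphenyl on a carbon with a double bond to nitrogen. For the measured compounds named here, no measured step bears on this change in a readable way: the changes from methyl through methoxy to nitro on the phenyl ring have left every value at the limit. Compound 4 is therefore expected to show a step of a number no higher from compound 2 to compound 4 (the limit leaves the size open), that is none beyond the scatter. Compound 4 is expected to give 100000 nM in this assay, between 50000 nM and 300000 nM, and most likely to be reported only as a limit.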

Compound 4, concentration lethal to 50% of the cells: 45900 nM
Compound 4: the middle estimate sits 2.2-fold (0.34 log units) above what was measured; measured number below the stated range.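

With 3-chlorophenyl on the carbon with a double bond to nitrogen, this position gives its first readable difference in this assay: the change from 4-methoxyphenyl gives an at least 2.1-fold lower number from compound 2 to compound 4 (0.33 log units; beyond the scatter). The change from 2-nitrophenyl gives an at least 2.1-fold lower number from compound 3 to compound 4 (0.33 log units; beyond the scatter), and the change from 4-methylphenyl gives an at least 2.1-fold lower number from compound 1 to compound 4 (0.33 log units; beyond the scatter), so less compound is tolerated with 3-chlorophenyl than with any of the three earlier groups. Compound 4 is the only one of the four that gives a number rather than a limit: the limit of > 100000 nM in this assay, at which 3 of the 4 values shown sit.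

As far as these compounds go, the full size of these three steps stays open, and the steps among compound 1, compound 2 and compound 3 cannot be read at all. Also open, from the compounds shown here alone, are whether the chlorine or its place on the ring accounts for the change, and what an amine or a carboxylic acid on the phenyl ring would give.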